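A few compounds are considered here, and "the series" means these few. Any claim that something is new, unique, unknown or untested is made for them only; others in the source may bear on it.

Measured so far:
compound 1 `CCOc1cc(NC(=O)NCc2cc(C)c(-c3cn(C)nc3C(F)(F)F)cn2)cc(Cl)n1` — 22 nM
compound 2 `CCOc1cc(NC(=O)NCc2cc(C)c(-c3cn(C)nc3C(F)(F)F)nn2)cc(C#N)n1` — 35 nM

Both numbers come from a functional assay on HFL1 cells for antagonist activity at sphingosine 1-phosphate receptor 2 (Homo sapiens), read by ELISA, with a stated time of 24 h, in the absence of a further agent; on this read-out higher numbers stand for weaker inhibition and lower numbers for stronger inhibition. Compound 2 has the highest of the two numbers, but compound 1 sits within the scatter of it, so no order between them can be read. Compound 3 `CCOc1nc(Cl)cc(NC(=O)NCc2cc(C)c(-c3cn(C)nc3C(F)(F)F)nn2)c1C` awaits measurement; it differs from compound 2 by 6-chloro-2-ethoxy-3-methylpyridin-4-yl in place of 2-cyano-6-ethoxypyridin-4-yl on an amide-type nitrogen. Among the measured compounds shown here, no step between measured compounds is available to size this change; the chloro-bearing compound 1 and the nitrile-bearing compound 2 give values within the scatter of each other, so the step is expected to be small, in either direction or none beyond the scatter. For compound 3 the expected value is 40 nM, with a range of 12 nM to 130 nM. This estimate means an expected step of a 1.1-fold higher number from compound 2 to compound 3 (0.06 log units; within the scatter).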

Compound 3, half-maximal inhibitory concentration: 15 nM
Compound 3: the middle estimate sits 2.7-fold (0.43 log units) above what was measured; the range from low to high includes it.
By their numbers in this assay, from the lowest: compounds 3, 1 and 2 (each within the scatter of the next, the first and the last beyond it).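

Among the compounds shown here, on the amide-type nitrogen, 6-chloro-2-ethoxy-3-methylpyridin-4-yl in place of 2-cyano-6-ethoxypyridin-4-yl gives a 2.3-fold lower number from compound 2 to compound 3 (0.37 log units; beyond the scatter) in this assay, the only step so far and one beyond the scatter. The group on this nitrogen can therefore move the read-out, and the change favours the chloro- and methyl-bearing group. Nothing shown accounts for the step.

From the compounds shown here alone, the change replaces the nitrile with chlorine and brings in a methyl at once, so which of these carries the step remains open. Also open, going by these compounds, is how an amine or a longer alkoxy chain in place of the ethoxy group would read.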